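The source may hold more compounds than are shown below. What is called first, only, known or untested is meant among the compounds shown, and "the series" means these compounds.

Compound 3 `N[C@H](CCO)C(=O)NCc1ccccc1` stands only at a limit among the values shown. In a functional assay on the whole organism (strain NMRI) for inhibition, with Mus musculus as the target, in the formalin test, with a stated time of 30 min (on this read-out lower numbers stand for an effect already at smaller amounts and higher numbers for an effect only at larger amounts of compound), compound 3 gives > 67 mg/kg, which is a limit of the assay and not a number. Compound 1 `CCC[C@@H](N)C(=O)NCc1ccccc1` gives 35 mg/kg in this assay. Compound 2 `NCC(N)C(=O)NCc1ccccc1` has no result in this assay, reported as "not determined" (no result reported).

For the measured compounds named here, the single measured step that bears on the next change is an at least 1.9-fold higher number from compound 1 to compound 3 (0.28 log units; that floor lies within the scatter), which rests on (the limit of > 67 mg/kg in this assay, at which 1 of the 3 values shown sits). Compound 4 `CCC[C@H](N)C(=O)NCc1ccccc1` differs from compound 3 by 1-aminobutyl in place of 1-amino-3-hydroxypropyl on a carbonyl carbon. This is the reverse of the measured step, with the hydroxy-bearing chain leaving and the plain 1-aminobutyl chain entering, so a move toward smaller numbers is expected, though the measured step gives only a floor for its size. Going by the values given here, compound 4 and compound 1 both carry the 1-aminobutyl group and differ in the sense of their single stereocentre, and the series holds no pair of compounds from which the size of such a difference can be read, so the expectation stays wide.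

The step from compound 3 is expected as an at least 1.3-fold lower number from compound 3 to compound 4 (0.12 log units; that floor lies within the scatter) in this assay. Compound 4 is estimated at 50 mg/kg in this assay, within 20 mg/kg to 150 mg/kg.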

Compound 4, dose for half-maximal effect: 100 mg/kg
For compound 4 the middle estimate is 2.0-fold (0.30 log units) below the measured one; low and high end bracket the measured number.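

For the compounds shown here, the change of drawn configuration alone carries a 2.9-fold higher number from compound 1 to compound 4 (0.46 log units; beyond the scatter) in this assay, the first readable step, and it shows that the sense of the single stereocentre on the 1-aminobutyl chain matters on this read-out, with compound 1 acting at the smaller dose. This gap can be assigned to configuration and to nothing else, because no other feature changes: the fact that compounds 1 and 4 differ only in the configuration as drawn
Compound 3 stands at > 67 mg/kg, a limit and not a number, so its step to compound 4 cannot be read and the swap of 1-amino-3-hydroxypropyl for 1-aminobutyl in this configuration stays without a size: the limit of > 67 mg/kg in this assay, at which 1 of the 4 values shown sits.

Going by these compounds alone, whether the configuration of compound 1 also gives the smaller number with another chain on the carbonyl carbon stays open, as this single pair is the only comparison of configuration, and compound 2 has no result to add. Also open, on these data alone, is how a longer chain, or a chain carrying a carboxylic acid, would behave in either configuration in this assay.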